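Para-substituent variation on the triazole-linked phenyl ring

The source may report more compounds than this note shows. Statements on the series, on what has been measured and on what is new or still open speak of the compounds shown alone.

Measured compounds:
compound 1 `COc1ccc(/C=C\C(=O)O)c(OCc2cn(-c3ccc(NC(=O)c4ccccc4)cc3)nn2)c1CC=C(C)C` with 23300 nM in a functional assay on T47D cells (Homo sapiens) for cytotoxicity, read by MTT assay, with a stated time of 24 h; on this read-out higher numbers stand for weaker inhibition and lower numbers for stronger inhibition
compound 2 `COc1ccc(/C=C\C(=O)O)c(OCc2cn(-c3ccccc3)nn2)c1CC=C(C)C` with 34100 nM in this assay

Within the data shown here, compound 2 stands beside compound 1, the only other measured compound, and the step of a 1.5-fold higher number from compound 1 to compound 2 (0.17 log units; within the scatter) lies within the scatter. Compound 3 `COc1ccc(/C=C\C(=O)O)c(OCc2cn(-c3ccc(C#N)cc3)nn2)c1CC=C(C)C` differs from compound 2 by cyano in place of hydrogen on an aromatic carbon. Among the measured compounds shown here, the only step that bears on a change at this position is a 1.5-fold higher number from compound 1 to compound 2 (0.17 log units; within the scatter), which was within the scatter. A step of comparable size is therefore expected in this assay, with no clear direction beyond the scatter. Compound 3 is estimated at 30000 nM, within 12000 nM to 75000 nM, an expected step of a 1.1-fold lower number from compound 2 to compound 3 (0.06 log units; within the scatter).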

Compound 3, half-maximal inhibitory concentration: 10200 nM
Estimate against measurement, compound 3: 2.9-fold (0.47 log units) above; the whole stated range lies above it.
By their numbers in this assay, from the lowest: compound 3; then compounds 1 and 2 (each within the scatter of the next).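

Going from phenyl to 4-cyanophenyl gives the first step at this position that lies beyond the scatter in this assay (a 3.3-fold lower number from compound 2 to compound 3 (0.52 log units; beyond the scatter)). Cyano also stands apart from benzamido at the same place (a 2.3-fold lower number from compound 1 to compound 3 (0.36 log units; beyond the scatter)), although benzamido and hydrogen could not be told apart, so what sits here can shift the number, if only modestly. Nothing measured here explains this. The compounds shown leave open whether an amine, a carboxylic acid or a chlorine atom at this place would move the number as cyano does.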